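A few compounds are considered here, and "the series" means these few. Any claim that something is new, unique, unknown or untested is made for them only; others in the source may bear on it.

Values in a functional assay on MKN-45 cells (Homo sapiens) for cytotoxicity; a lower number here means a stronger inhibitor, a higher number a weaker inhibitor:

- Compound 1 `COc1ccc(S(=O)(=O)N2CCc3cccc(NC(=O)C(C)(C)C)c32)cc1`: 289 nM
- Compound 2 `COc1ccc(S(=O)(=O)N2CCc3cccc(NC(=O)Oc4ccccc4)c32)cc1`: > 10000 nM
- Compound 3 `COc1ccc(S(=O)(=O)N2CCc3cccc(NC(=O)c4ccncc4)c32)cc1`: 8.8 nM
- Compound 4 `COc1ccc(S(=O)(=O)N2CCc3cccc(NC(C)=O)c32)cc1`: not yet measured

Going by the values given here, compound 3 has the lowest number so far at 8.8 nM, ahead of compound 1 at 289 nM. The entry for compound 2, > 10000 nM, is a limit of the assay (the limit of > 10000 nM in this assay, at which 1 of the 3 values shown sits).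

The next step replaces pyridin-4-yl with methyl on a carbonyl carbon, turning (pyridin-4-yl)carbonyl into acetyl: methyl in place of pyridin-4-yl on a carbonyl carbon.

Among the compounds with values here, the nearest precedent is a 33-fold lower number from compound 1 to compound 3 (1.52 log units; beyond the scatter), a large step that exchanges tert-butyl for pyridin-4-yl. The step of an at least 1100-fold lower number from compound 2 to compound 3 (3.05 log units; beyond the scatter) is larger still but rests on a limit, as does an at least 34-fold higher number from compound 1 to compound 2 (1.53 log units; beyond the scatter). Both confirm that the group on this carbonyl carbon can shift the number strongly. Methyl has not been tested here, and tert-butyl is only a rough guide to it.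

In this assay, a large rise is expected, estimated as a 34-fold higher number from compound 3 to compound 4 (1.53 log units; beyond the scatter). The estimate for compound 4 is 300 nM, with an expected range of 50 nM to 3000 nM.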

Compound 4, half-maximal inhibitory concentration: 61 nM
Compound 4: middle estimate off by 4.9-fold (0.69 log units), on the high side; the range from low to high includes it.
By their numbers in this assay, from the lowest: compound 3; then compound 4; then compound 1. At a limit, above all of these: compound 2.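

In this assay, the step of a 4.7-fold lower number from compound 1 to compound 4 (0.68 log units; beyond the scatter) shows that tert-butyl is a poor stand-in for methyl on this carbonyl carbon, and that a group without a ring can still give a low number. Pyridin-4-yl keeps its lead, with a 6.9-fold higher number from compound 3 to compound 4 (0.84 log units; beyond the scatter), so the order among the three groups with numbers does not follow the size of the group alone: pyridin-4-yl, then methyl, then tert-butyl. With phenoxy, the entry for compound 2 is a limit, and an at least 160-fold lower number from compound 2 to compound 4 (2.21 log units; beyond the scatter) is only a bound: the limit of > 10000 nM in this assay, at which 1 of the 4 values shown sits.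

As far as these compounds go, whether the ring nitrogen of pyridin-4-yl matters stays open, and a plain phenyl on this carbonyl carbon would separate it from the ring itself. Also open, from the compounds shown here alone, is where ethyl, a longer chain or a pyridin-3-yl group would fall.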